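From ethoxy to fluoro: estimating compound 3

The source may report more compounds than this note shows. Statements on the series, on what has been measured and on what is new or still open speak of the compounds shown alone.

In a physicochemical assay for lipophilicity, read by HPLC, at pH 7 (a higher number here means a more lipophilic compound, a lower number a more polar compound), compound 1 `CCS(=O)(=O)c1ccc(OCC[C@@H]2C[C@@H]2C2CCN(c3nc(C(C)C)no3)CC2)c(F)c1` gives 4.2 and compound 2 `CCOc1cnc(N2CCC([C@H]3C[C@H]3COCc3ccc(S(C)(=O)=O)c(F)c3)CC2)nc1` gives 4.2, so compound 2 stands level with compound 1. Compound 3 `CS(=O)(=O)c1ccc(COC[C@@H]2C[C@@H]2C2CCN(c3ncc(F)cn3)CC2)cc1F` has not been measured yet. It carries fluoro in place of ethoxy on an aromatic carbon, turning 5-ethoxypyrimidin-2-yl into 5-fluoropyrimidin-2-yl (fluoro in place of ethoxy on an aromatic carbon). Among the compounds with values here, no measured pair differs in one place only, so the expectation rests on this structural change alone. In this assay, a small downward step is expected a number 0.20 log units lower from compound 2 to compound 3 (within the scatter), within the scatter. For compound 3 the estimated value is 4, with a range of 3.6 to 4.4.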

Compound 3, distribution coefficient: 4.2
The estimate for compound 3 lay 0.20 log units below the measured number; low and high end bracket the measured number.
By their numbers in this assay, from the lowest: compounds 1, 2 and 3 (each within the scatter of the next).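

In this assay, within the data shown here, the change from 5-ethoxypyrimidin-2-yl to 5-fluoropyrimidin-2-yl gives no change at the digits printed from compound 2 to compound 3 (within the scatter) and is the first step here that differs in one place only. On this aromatic carbon, a group of 3 heavy atoms with 1 hydrogen-bond acceptor gives way to a single fluorine atom with no hydrogen-bond acceptor, and the reading stays put for this pair. Going by these compounds, whether an amine, a carboxylic acid or a longer chain such as butoxy on the same carbon would also leave the reading in place stays open. Nothing at hand accounts for the two groups reading alike.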